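Carbonyl substituent swaps in the antiproliferative series

The compounds below may be only part of what the source reports. "The series", "measured", "known", "first", "only" and "open" are said of these compounds alone.

Measured in a functional assay on BaF3 cells (Mus musculus) for antiproliferative activity, read by CCK-8 assay and cell counting, with a stated time of 76 h; a lower number here means a stronger inhibitor, a higher number a weaker inhibitor:
- compound 1 `COc1cc2nccc(Oc3ccc(Nc4nn(C)cc4C(=O)N4CCCCC4)cc3)c2cc1C(N)=O` gives 5650 nM
- compound 2 `COc1cc2nccc(Oc3ccc(Nc4nn(C)cc4C(=O)Nc4ccc(F)cc4)cc3)c2cc1C(N)=O` gives 3060 nM
- compound 3 `COc1cc2nccc(Oc3ccc(Nc4nn(C)cc4C(=O)N4CCCC5CCCCC54)cc3)c2cc1C(N)=O` gives 4330 nM

Compound 3 stands within the scatter of both other compounds, as shown by a 1.3-fold lower number from compound 1 to compound 3 (0.12 log units; within the scatter) and by a 1.4-fold higher number from compound 2 to compound 3 (0.15 log units; within the scatter). The next structure is compound 4 `COc1cc2nccc(Oc3ccc(Nc4nn(C)cc4C(=O)NCC4CCCCC4)cc3)c2cc1C(N)=O`, and the change is a group of 8 heavy atoms (7 carbon, 1 nitrogen; one six-membered non-aromatic ring of carbon only) in place of a group of 10 heavy atoms (9 carbon, 1 nitrogen; one six-membered non-aromatic ring of carbon only, one six-membered non-aromatic ring with 1 hetero atom), on a carbonyl carbon. Going by the values given here, no measured compound carries (cyclohexylmethyl)amino, so the data hold no direct precedent for this group.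

The closest guide is a 1.8-fold lower number from compound 1 to compound 2 (0.27 log units; within the scatter), where (4-fluorophenyl)amino replaces piperidin-1-yl on a carbonyl carbon. The two steps to compound 3 bear on the change as well, since they also exchange the group on that carbonyl carbon. All three steps lie within the scatter, so the group at this place has not yet moved the number measurably in this assay. On that basis, no change beyond the scatter is expected, and the estimated step is a 1.1-fold lower number from compound 3 to compound 4 (0.06 log units; within the scatter). Among the compounds with values here, this rests on only three compounds, so the range is kept wide.

For compound 4 the estimated value is 3800 nM, with an expected range from 1700 nM to 8000 nM.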

Compound 4, half-maximal inhibitory concentration: > 10000 nM
Compound 4: no number, only a limit; the forecaster's own chance of this, stated with the estimate: 5%; middle value at least 2.6-fold (0.42 log units) away from the limit.
By their numbers in this assay, from the lowest: compounds 2, 3 and 1 (each within the scatter of the next). At a limit, above all of these: compound 4.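

In this assay compound 4 is held only as a limit of the assay and not as a number: the limit of > 10000 nM in this assay, at which 1 of the 4 values shown sits. Even as floors, two of its steps pass the scatter, an at least 2.3-fold higher number from compound 3 to compound 4 (0.36 log units; beyond the scatter) and an at least 3.2-fold higher number from compound 2 to compound 4 (0.51 log units; beyond the scatter), whereas every earlier exchange on this carbonyl carbon stayed within it, so the group at this place can measurably change the reading. The step from compound 2 keeps the amide-type nitrogen and exchanges only the group on it, which ties that loss to cyclohexylmethyl in place of 4-fluorophenyl, while the comparison with the piperidin-1-yl amide is less firm, with an at least 1.7-fold higher number from compound 1 to compound 4 (0.24 log units; that floor lies within the scatter).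

From the compounds shown here alone, the true size of all three steps stays unknown, since compound 4 has no number. Also open, going by these compounds, is whether benzyl or plain cyclohexyl on the amide-type nitrogen, or a basic amine such as 4-methylpiperazin-1-yl on the carbonyl carbon, would give a reading that falls with the other compounds or one that moves clearly below them.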